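Working notes: from compound 3 to compound 4

The source may report more compounds than this note shows. Statements on the series, on what has been measured and on what is new or still open speak of the compounds shown alone.

Values in a functional assay on A549 cells (Homo sapiens) for antiproliferative activity, read by MTT assay, with a stated time of 24 h; a lower number here means a stronger inhibitor, a higher number a weaker inhibitor:
- compound 1 `O=C(NNc1cccc(Cl)c1)c1cccc(NS(=O)(=O)c2cnc(O)nc2O)c1`: 6640 nM
- compound 2 `O=C(NNc1ccc(F)cc1)c1cccc(NS(=O)(=O)c2cnc(O)nc2O)c1`: > 20000 nM (a limit of the assay)
- compound 3 `CCCCOc1ccc(C(=O)NNC(=O)c2cccc(NS(=O)(=O)c3cnc(O)nc3O)c2)cc1`: 7760 nM
- compound 4 `O=C(NNC(=O)c1cccc(NS(=O)(=O)c2cnc(O)nc2O)c1)c1cccc(Cl)c1`: not yet measured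

Compound 3 gives 7760 nM and compound 1 gives 6640 nM, two values within the scatter of each other. Compound 2 gives > 20000 nM, which is a limit and not a number.

The change to compound 4 is 3-chlorophenyl in place of 4-butoxyphenyl on a carbonyl carbon. Among the measured compounds shown here, the one measured step, an at least 3.0-fold higher number from compound 1 to compound 2 (0.47 log units; beyond the scatter), is 4-fluorophenyl in place of 3-chlorophenyl on an amine nitrogen. It sits at a different place, so it bears on this change only loosely, but it shows that a swap of one aryl group can move the number in this assay beyond the scatter. For the measured compounds named here, no measured step covers the loss of 4-butoxyphenyl. Compound 1, which carries 3-chlorophenyl on the amine nitrogen, gives 6640 nM, close to the starting point. A shift beyond the scatter is therefore not expected in this assay, and no direction is favoured, although the range stays wide on the strength of an at least 3.0-fold higher number from compound 1 to compound 2 (0.47 log units; beyond the scatter).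

The expected step is a 1.0-fold higher number from compound 3 to compound 4 (0.01 log units; within the scatter). For compound 4 the estimated value is 8000 nM, with an expected range of 3500 nM to 19000 nM.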

Compound 4, half-maximal inhibitory concentration: 6000 nM
The estimate for compound 4 lay 1.3-fold (0.12 log units) above the measured number; measured number inside the range.
By their numbers in this assay, from the lowest: compounds 4, 1 and 3 (each within the scatter of the next). At a limit, above all of these: compound 2.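

In this assay, the carbonyl carbon whose other neighbour is an amide-type nitrogen accepts a large exchange of aryl group without a shift beyond the scatter: with 3-chlorophenyl (7 heavy atoms) in place of 4-butoxyphenyl (11 heavy atoms), the result is a 1.3-fold lower number from compound 3 to compound 4 (0.11 log units; within the scatter). The (3-chlorophenyl)carbonyl group in place of 3-chlorophenyl on an amine nitrogen also leaves the number within the scatter, at a 1.1-fold lower number from compound 1 to compound 4 (0.04 log units; within the scatter), whereas the same group in place of 4-fluorophenyl gives an at least 3.3-fold lower number from compound 2 to compound 4 (0.52 log units; beyond the scatter), which lies beyond the scatter. Compound 2 stands at a limit of the assay: the limit of > 20000 nM in this assay, at which 1 of the 4 values shown sits.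

The compounds shown do not separate the effect of the aryl group from that of the carbonyl in the 2>4 comparison, and 4-fluorophenyl on the carbonyl carbon would be the direct test. On these data alone, it also remains open whether an amine or a carboxylic acid on this aryl ring, or an alkoxy chain longer than butoxy, would move the number in this assay beyond the scatter.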